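Swapping the ring on the amide nitrogen of compound 3

The source may hold more compounds than are shown below. What is called first, only, known or untested is meant among the compounds shown, and "the series" means these compounds.

Measured compounds:
compound 1 `Cc1ccc(S(=O)(=O)N2C=CNC(=O)[C@H]2CC(=O)N[C@@H]2CCc3ccccc32)cc1` gives 94.7 nM in an in vitro functional assay on cells for antagonist activity at B1 bradykinin receptor (Homo sapiens), read by luminescence and calcium flux, with a stated time of 2 h; on this read-out higher numbers stand for weaker inhibition and lower numbers for stronger inhibition
compound 2 `Cc1ccc(S(=O)(=O)N2C=CNC(=O)[C@H]2CC(=O)NC2CCCCC2)cc1` gives 990 nM in this assay
compound 3 `Cc1ccc(S(=O)(=O)N2C=CNC(=O)[C@H]2CC(=O)NC2CCOCC2(C)C)cc1` gives 25.2 nM in this assay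

Compound 3 stands lowest of the three, with both gaps beyond the scatter, so it is the strongest inhibitor measured here. Compound 4 `Cc1ccc(S(=O)(=O)N2C=CNC(=O)[C@H]2CC(=O)N[C@H]2CCN(C)CC2(C)C)cc1` differs from it by a group of 9 heavy atoms (8 carbon, 1 nitrogen; one six-membered non-aromatic ring with 1 hetero atom) in place of a group of 8 heavy atoms (7 carbon, 1 oxygen; one six-membered non-aromatic ring with 1 hetero atom), on an amide-type nitrogen. Among the compounds with values here, the steps that bear on this position are a 3.8-fold lower number from compound 1 to compound 3 (0.57 log units; beyond the scatter) and a 39-fold lower number from compound 2 to compound 3 (1.59 log units; beyond the scatter), both showing that the group on this nitrogen moves the result strongly. The oxygen-containing ring of compound 3 has not been swapped for a nitrogen-containing ring elsewhere in these data, so the direction is uncertain; a modest step is expected, and compound 4 is estimated at 45 nM (range 10 nM to 200 nM), a step of a 1.8-fold higher number from compound 3 to compound 4 (0.25 log units; within the scatter).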

Compound 4, half-maximal inhibitory concentration: 0.42 nM
Compound 4: the middle estimate sits 110-fold (2.03 log units) above what was measured, and the stated range ends above it.
By their numbers in this assay, from the lowest: compound 4; then compound 3; then compound 1; then compound 2.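

Within the data shown here, putting a ring nitrogen in place of the ring oxygen gives a 60-fold lower number from compound 3 to compound 4 (1.78 log units; beyond the scatter), so the atom in this ring matters far more than the earlier compounds could show. The same group also stands well clear of the cyclohexyl and 2,3-dihydro-1H-inden-1-yl groups, with a 2400-fold lower number from compound 2 to compound 4 (3.37 log units; beyond the scatter) and a 230-fold lower number from compound 1 to compound 4 (2.35 log units; beyond the scatter). Nothing available here accounts for the size of this step.

The entering group also brings a defined stereocentre, so the compounds shown do not separate its share from that of the ring nitrogen. They also leave open how an acetyl group in place of the methyl on that ring nitrogen would compare.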